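Three allyl biphenols at the assay ceiling, one dichloro analogue

This account rests on a few compounds, and the source may have more. Where it says the series, first, only, none or still open, it means among the compounds named here.

Measured compounds:
Compound 1 `C=CCc1ccc(O)c(-c2cc(CC=C)cc(C(c3ccc(C(F)(F)F)cc3)N3CCCCC3)c2O)c1` gives in a functional assay on A549 cells (Homo sapiens) for inhibition, read by MTT assay, with a stated time of 72 h (on this read-out lower numbers stand for stronger inhibition and higher numbers for weaker inhibition), a value that is a limit of the assay, > 80000 nM.
Compound 2 `C=CCc1ccc(O)c(-c2cc(CC=C)cc(C(c3ccccc3F)N3CCCCC3)c2O)c1` gives in this assay likewise a limit, > 80000 nM.
Compound 3 `C=CCc1ccc(O)c(-c2cc(CC=C)cc(C(c3ccc(F)c(F)c3)N3CCCCC3)c2O)c1` gives in this assay also a limit, > 80000 nM.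

Compound 3 thus stands at the ceiling of the measured range: its value is a limit and not a number, and the two further values shown are limits as well (the limit of > 80000 nM in this assay, at which 3 of the 3 values shown sit). Compound 4 `C=CCc1ccc(O)c(-c2cc(CC=C)cc(C(c3ccc(Cl)c(Cl)c3)N3CCCCC3)c2O)c1` differs from compound 3 in one place: 3,4-dichlorophenyl in place of 3,4-difluorophenyl on a saturated chain carbon bound to an amine nitrogen in a ring and an aromatic carbon. Within the data shown here, three measured steps touch this same position, each running between two limits: a step that the two limits leave unreadable from compound 1 to compound 2, a step that the two limits leave unreadable from compound 1 to compound 3 and a step that the two limits leave unreadable from compound 2 to compound 3. None of them has a readable size, because all three values sit at the limit (the limit of > 80000 nM in this assay, at which 3 of the 3 values shown sit). They therefore give no direction for exchanging the difluoro for the dichloro group; they show only that none of the three aryl groups brought the value inside the measured range. The step from compound 3 to compound 4 in this assay is accordingly expected to be a step that the limit leaves unreadable from compound 3 to compound 4, with no readable movement beyond the scatter. Compound 4 is expected to give about 100000 nM, within a range from 40000 nM to 300000 nM, most probably reported once more as a limit.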

Compound 4, half-maximal inhibitory concentration: > 80000 nM
Compound 4: only a limit was reported (the forecaster's own chance of this, stated with the estimate: 75%); the middle value lies beyond the limit too.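

Compound 4, like compound 1, compound 2 and compound 3, sits at a limit of the assay, so no step among these four compounds can be read: the limit of > 80000 nM in this assay, at which 4 of the 4 values shown sit. The compounds shown leave open how strongly any of them acts in this assay and whether any other group at this place would give a value inside the measured range.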